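A Larger Azole in Place of Methoxy on the Shared Core

This account rests on a few compounds, and the source may have more. Where it says the series, first, only, none or still open, it means among the compounds named here.

Compound 1 `CNc1nc(NC2CCCC2)nc(NC2(C#N)CCCCC2)n1`: in an in vitro assay on Sf21 cells for inhibition of high affinity 3',5'-cyclic-AMP phosphodiesterase 7A (Homo sapiens) (on this read-out higher numbers stand for weaker inhibition and lower numbers for stronger inhibition), compound 1 reaches only the limit > 5000 nM.
Compound 2 `CNc1nc(NC2(C#N)CCCCC2)nc(-n2ccnc2)n1`: in this assay compound 2 gives 1050 nM.
Compound 3 `CNc1nc(NC2(C#N)CCCCC2)nc(OC)n1`: in this assay compound 3 gives 521 nM.

Among the measured compounds shown here, compound 3 holds the lowest of the two numbers measured so far; its nearest neighbour is compound 2, and the step of a 2.0-fold lower number from compound 2 to compound 3 (0.30 log units; within the scatter) lies within the scatter. The value of compound 1 is a limit rather than a number (the limit of > 5000 nM in this assay, at which 1 of the 3 values shown sits). Compound 4 `CNc1nc(NC2(C#N)CCCCC2)nc(-n2cnc(C#N)n2)n1` differs from compound 3 by 3-cyano-1H-1,2,4-triazol-1-yl in place of methoxy on an aromatic carbon. For the measured compounds named here, three measured steps bear on this change. an at least 9.5-fold lower number from compound 1 to compound 3 (0.98 log units; beyond the scatter) and an at least 4.7-fold lower number from compound 1 to compound 2 (0.67 log units; beyond the scatter) show that both methoxy and an azole in place of cyclopentylamino lower the number at least modestly, while a 2.0-fold lower number from compound 2 to compound 3 (0.30 log units; within the scatter) shows that the azole and the methoxy end up within the scatter of each other. The entering group is again a five-membered aromatic ring on the same carbon, so in this assay no step beyond the scatter is expected from compound 3 to compound 4, a 1.3-fold higher number from compound 3 to compound 4 (0.13 log units; within the scatter). Compound 4 is therefore estimated at 700 nM, with a range from 250 nM to 2500 nM.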

Compound 4, half-maximal inhibitory concentration: > 5000 nM
Compound 4: only a limit was reported; the forecaster's own chance of this, stated with the estimate: 5%; middle value at least 7.1-fold (0.85 log units) away from the limit.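

Putting 3-cyano-1H-1,2,4-triazol-1-yl on this carbon in place of methoxy gives an at least 9.5-fold higher number from compound 3 to compound 4 (0.98 log units; beyond the scatter) and in place of 1H-imidazol-1-yl gives an at least 4.7-fold higher number from compound 2 to compound 4 (0.67 log units; beyond the scatter) in this assay as the read-out. The earlier compounds shown here, in which an azole and methoxy stayed within the scatter of each other, could not show this: at this position, between two ring nitrogen atoms, a five-membered aromatic ring does not by itself keep the number low, and one azole differs clearly from another. Compound 4 joins compound 1 at a limit, so the step between those two cannot be read: the limit of > 5000 nM in this assay, at which 2 of the 4 values shown sit.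

Still open, as far as these compounds go, is whether the nitrile or the triazole ring itself accounts for the weaker inhibition, a question that plain 1H-1,2,4-triazol-1-yl would address. Also open, from the compounds shown here alone, is how ethoxy or dimethylamino would compare with methoxy on this carbon.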